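The source may hold more compounds than are shown below. What is called first, only, known or untested is meant among the compounds shown, and "the series" means these compounds.

Compound 1 `COc1ccc([C@@H]2CC(=O)c3c(O)cc(OC(=O)c4ccccc4)cc3O2)cc1O` gives 16500 nM
Compound 2 `COc1ccc([C@@H]2CC(=O)c3c(O)cc(OC(=O)c4ccccc4)cc3O2)cc1OC(=O)c1ccccc1` gives 46000 nM

Among the measured compounds shown here, in a functional assay on HCT-116 cells (Homo sapiens), read by crystal violet staining, with a stated time of 6 days (on this read-out higher numbers stand for weaker inhibition of growth and lower numbers for stronger inhibition of growth), compound 1 holds the lower of the two numbers so far. Compound 3 `C/C=C/C(=O)Oc1cc(O)c2c(c1)O[C@H](c1ccc(OC)c(O)c1)CC2=O`, not yet measured, has prop-1-en-1-yl in place of phenyl on a carbonyl carbon and keeps the rest of compound 1. For the measured compounds named here, the only measured step, a 2.8-fold higher number from compound 1 to compound 2 (0.45 log units; beyond the scatter), comes from benzoyl in place of hydrogen on an oxygen on an aromatic ring. Going by the values given here, it bears only indirectly, and no measured step tests this exchange, so no change beyond the scatter is expected in this assay. The expected step is a 1.1-fold higher number from compound 1 to compound 3 (0.04 log units; within the scatter) as a working estimate. For compound 3 the estimated value is 18000 nM, with an expected range of 7000 nM to 45000 nM.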

Compound 3, concentration for 50% growth inhibition: 16900 nM
The estimate for compound 3 lay 1.1-fold (0.03 log units) above the measured number; low and high end bracket the measured number.
By their numbers in this assay, from the lowest: compounds 1 and 3 (each within the scatter of the next); then compound 2.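

In this assay, prop-1-en-1-yl in place of phenyl on the carbonyl carbon gives a 1.0-fold higher number from compound 1 to compound 3 (0.01 log units; within the scatter) and so leaves the read-out unmoved. For this pair, the phenyl ring is therefore not required at this position to keep the growth-inhibition number of compound 1, and an open-chain alkenyl group serves equally well. Nothing measured on hand accounts for this equivalence.

Still open, going by these compounds, is whether a longer chain such as hexanoyl, or an amine carried on the acyl group, would hold the number. Also open, on these data alone, is what a free hydroxyl in place of this ester would do.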